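A few compounds are considered here, and "the series" means these few. Any claim that something is new, unique, unknown or untested is made for them only; others in the source may bear on it.

Measured compounds:
compound 1 `COc1ccc(-c2ccc(S(=O)(=O)N[C@H]3C[C@@H](N=C=S)C3)nc2)cc1`: 6.3 nM
compound 2 `Fc1cc(-c2cccc(OCc3ccccc3)c2)ccc1CO[C@H]1C[C@@H](N=C=S)C1`: 99.8 nM
compound 3 `COc1ccc(-c2ccc(C(=O)N[C@H]3C[C@@H](N=C=S)C3)nc2)cc1F`: 26.6 nM

These three were tested in an assay on isolated protein for inhibition of N-acylethanolamine-hydrolyzing acid amidase (Homo sapiens), read by fluorescence, with a stated time of 90 min; on this read-out higher numbers stand for weaker inhibition and lower numbers for stronger inhibition. Compound 2 gives the highest number of the three, so it is the weakest inhibitor here; compound 3 sits nearest to it, and compound 1 furthest, both at lower numbers.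

Compound 4 `Fc1cc(-c2cccc(C(F)(F)F)c2)ccc1CO[C@H]1C[C@@H](N=C=S)C1` has not yet been measured. It differs from compound 2 in one place: trifluoromethyl in place of benzyloxy on an aromatic carbon. Going by the values given here, no measured pair shows this exact change, so the size of the step is uncertain. A modest shift toward a higher number, weaker inhibition, is expected, at the edge of the usual scatter: a step of a 2.0-fold higher number from compound 2 to compound 4 (0.30 log units; within the scatter). Compound 4 is therefore estimated at 200 nM, within a range from 50 nM to 800 nM.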

Compound 4, half-maximal inhibitory concentration: 67.2 nM
Beside the measured number, compound 4's estimate is 3.0-fold (0.47 log units) above it; measured number inside the range.
By their numbers in this assay, from the lowest: compound 1; then compound 3; then compounds 4 and 2 (each within the scatter of the next).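

In this assay, trifluoromethyl in place of benzyloxy on this aromatic carbon gives a 1.5-fold lower number from compound 2 to compound 4 (0.17 log units; within the scatter) and so does not clearly change the read-out. This position therefore accepts a smaller group with no ring, and inhibition at this level does not depend on the benzyloxy ring or its oxygen. Nothing measured here explains why the two groups read alike. Open, going by these compounds, is how an amine, a carboxylic acid or a longer chain at this position would read, and whether a plain hydrogen would serve as well.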